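This account rests on a few compounds, and the source may have more. Where it says the series, first, only, none or still open, it means among the compounds named here.

In a functional assay on HCT-116 cells (Homo sapiens) for inhibition (a higher number here means that more compound is needed for the effect, a lower number that less compound is needed), compound 1 (`COc1cc(N2CCN(C(=O)C3CCC(O)CC3)CC2)ccc1Nc1nc(NC2CCCCC2)c2nc[nH]c2n1`) gives 14 nM, compound 2 (`COc1cc(N2CCC(C(=O)N3CCC(N(C)C)C3)CC2)ccc1Nc1nc(NC2CCCCC2)c2nc[nH]c2n1`) gives 77 nM and compound 3 (`COc1cc(N2CCC(C(=O)N3CCOCC3)CC2)ccc1Nc1nc(NC2CCCCC2)c2nc[nH]c2n1`) gives 130 nM. Compound 3 thus stands within the scatter of compound 2, while the number of compound 1 is lower than that of compound 3 by more than the scatter.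

Compound 4 (`COc1cc(N2CCC(CC(=O)N3CCOCC3)CC2)ccc1Nc1nc(NC2CCCCC2)c2nc[nH]c2n1`) comes from compound 3 by a single change: ((morpholin-4-yl)carbonyl)methyl in place of (morpholin-4-yl)carbonyl on a saturated ring carbon. Going by the values given here, only one measured step links compounds that differ in one place, a 1.7-fold higher number from compound 2 to compound 3 (0.23 log units; within the scatter). That step lies within the scatter, but it replaces the group on the carbonyl carbon and so bears only indirectly on the new change. Among the compounds with values here, no measured pair tests the added carbon, so the data offer no basis for a direction, and no step beyond the scatter is expected in this assay. The estimated outcome is a 1.1-fold lower number from compound 3 to compound 4 (0.03 log units; within the scatter). For compound 4 the expected value is 120 nM, with an estimated range of 45 nM to 320 nM.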

Compound 4, half-maximal effective concentration: 70 nM
For compound 4 the middle estimate is 1.7-fold (0.23 log units) above the measured one; low and high end bracket the measured number.
By their numbers in this assay, from the lowest: compound 1; then compounds 4, 2 and 3 (each within the scatter of the next).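

In this assay, ((morpholin-4-yl)carbonyl)methyl in place of (morpholin-4-yl)carbonyl on a saturated ring carbon gives a 1.9-fold lower number from compound 3 to compound 4 (0.27 log units; within the scatter), so at this position the assay does not separate the two groups. The same holds when ((morpholin-4-yl)carbonyl)methyl replaces (3-(dimethylamino)pyrrolidin-1-yl)carbonyl, with a 1.1-fold lower number from compound 2 to compound 4 (0.04 log units; within the scatter), so neither the added carbon nor this exchange of groups moves the number beyond the scatter. No measurement at hand offers an explanation for either step.

The compounds shown leave open whether a longer chain carrying the morpholine amide at this ring carbon would also stay within the scatter of compound 3. They also leave open how a carboxylic acid in place of the morpholine amide would read in this assay.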